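From 2-chlorophenyl to 4-hydroxyphenyl on a shared core

This account rests on a few compounds, and the source may have more. Where it says the series, first, only, none or still open, it means among the compounds named here.

Compound 1 `C#CCSc1nc(Nc2ccccc2Cl)c2ccncc2n1` - 27600 nM
Compound 2 `C#CCSc1nc(Nc2ccccc2OC)c2ccncc2n1` - 3440 nM
Compound 3 `C#CCSc1nc(Nc2cccc(OC)c2)c2ccncc2n1` - 2070 nM

These values come from a functional assay on MGC-803 cells (Homo sapiens) for inhibition, read by MTT assay, with a stated time of 72 h (on this read-out lower numbers stand for stronger inhibition and higher numbers for weaker inhibition), where compound 1 has the highest number of the three. Compound 4 `C#CCSc1nc(Nc2ccc(O)cc2)c2ccncc2n1` remains unmeasured. It carries 4-hydroxyphenyl in place of 2-chlorophenyl on a nitrogen on an aromatic ring. The nearest measured step is the exchange of chloro for methoxy, an 8.0-fold lower number from compound 1 to compound 2 (0.90 log units; beyond the scatter). Compound 3 also carries methoxy, and its value lies within the scatter of that of compound 2. Going by the values given here, no compound with a hydroxy group has been measured. A step of similar size and the same direction is therefore expected, a 6.9-fold lower number from compound 1 to compound 4 (0.84 log units; beyond the scatter). The estimated value for compound 4 is 4000 nM, with an expected range from 1300 nM to 13000 nM.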

Compound 4, half-maximal inhibitory concentration: > 80000 nM
Compound 4: a limit, no number; the forecaster's own chance of this, stated with the estimate: 3%; middle value at least 20-fold (1.30 log units) from the limit.
By their numbers in this assay, from the lowest: compounds 3 and 2 (each within the scatter of the next); then compound 1. At a limit, above all of these: compound 4.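

Compound 4 gives > 80000 nM in this assay as a limit of the assay, not a number. Exchanging the group on a nitrogen on an aromatic ring for 4-hydroxyphenyl gives an at least 2.8-fold higher number from compound 1 to compound 4 (0.46 log units; beyond the scatter) and so runs the opposite way, whereas an 8.0-fold lower number from compound 1 to compound 2 (0.90 log units; beyond the scatter) came with methoxy. This shows that the number at this position can rise as well as fall, and the size of the rise is only a bound: the limit of > 80000 nM in this assay, at which 1 of the 4 values shown sits.

The change replaces the group and moves its place on the ring at once, so the compounds shown do not separate the two. As far as these compounds go, how 4-aminophenyl or 4-carboxyphenyl would read also stays open.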